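The source may report more compounds than this note shows. Statements on the series, on what has been measured and on what is new or still open speak of the compounds shown alone.

Measured compounds:
- Compound 1, `COc1cc2c(Oc3ccc(NC(=O)c4nccc(-c5ccc(C)cc5)n4)cc3F)ccnc2cc1OCCCN1CCCCC1`: 900 nM
- Compound 2, `COc1cc2c(Oc3ccc(NC(=O)c4nccc(-c5ccc(F)cc5)n4)cc3F)ccnc2cc1OCCCN1CCCCC1`: "not determined" (no result reported)
- Compound 3, `COc1cc2c(Oc3ccc(NC(=O)c4nccc(-c5ccc(C)cc5)n4)cc3F)ccnc2cc1OCCCN1CCN(C)CC1`: "not determined" (no result reported)

In a functional assay on A549 cells (Homo sapiens) for cytotoxicity, read by MTT assay, with a stated time of 72 h (a lower number here means a stronger inhibitor, a higher number a weaker inhibitor), compound 1 gives 900 nM. For compound 2 this assay gives "not determined" (no result reported), and for compound 3 it gives "not determined" (no result reported), so neither of these two compounds has a number of its own; compound 1 is the only anchor on the table.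

Compound 4, `COc1cc2c(Oc3ccc(NC(=O)c4nccc(-c5ccc(F)cc5)n4)cc3F)ccnc2cc1OCCCN1CCN(C)CC1`, has not yet been measured. It differs from compound 3 by fluoro in place of methyl on an aromatic carbon. Among the measured compounds shown here, no pair of measured compounds separated by a single change is available, so the size and direction of this step in this assay cannot be read from the data; the step is assumed to stay within the usual scatter, and the expectation leans on compound 1 alone, which carries two differences from compound 4. On that basis compound 4 is expected to give about 900 nM in this assay, with a wide range from 250 nM to 4000 nM.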

Compound 4, half-maximal inhibitory concentration: 680 nM
For compound 4 the middle estimate is 1.3-fold (0.12 log units) above the measured one; measured number inside the range.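

In this assay, among the compounds shown here, compound 3 has no number of its own, so no step from compound 3 to compound 4 can be read. Whether swapping 4-methylphenyl for 4-fluorophenyl changes cytotoxicity, in either direction, stays open, and no evidence shown here bears on this result.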